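Naphthyl for methoxyphenyl on a triazole-linked aminopyrimidine

The compounds below may be only part of what the source reports. "The series", "measured", "known", "first", "only" and "open" are said of these compounds alone.

Measured compounds:
compound 1, `COc1ccc(-c2cc(-c3ccc(OCc4cn(Cc5ccccc5)nn4)cc3O)nc(N)n2)cc1`: 42700 nM
compound 2, `O=C1CC(c2ccc(Br)cc2)Oc2cc(OCc3cn(Cc4ccc(Br)cc4)nn3)ccc21`: 87500 nM
compound 3, `C#CCOc1ccc(/C=C/C(=O)c2ccc(OCc3cn(CCCCCC)nn3)cc2O)cc1`: "not determined" (no result reported)

The account follows compound 1 into its analogue compound 4, `Nc1nc(-c2ccc(OCc3cn(Cc4ccccc4)nn3)cc2O)cc(-c2cccc3ccccc23)n1`. In an ADME assay on cells (Macrophage) for cytotoxicity, read by resazurin assay, with a stated time of 48 h (on this read-out lower numbers stand for higher toxicity in this test and higher numbers for lower toxicity in this test), compound 1 gives 42700 nM. Among the measured compounds shown here, this is the lower of the two numbers known; compound 2 gives 87500 nM, a difference beyond the usual scatter. For compound 3 the record gives "not determined" (no result reported), so its position cannot be stated.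

The change from compound 1 to compound 4 is naphthalen-1-yl in place of 4-methoxyphenyl on an aromatic carbon. For the measured compounds named here, no step between two measured compounds is known that could calibrate such a change, and compound 2 shares only the triazole linker with compound 1, so its value is of little guidance here. On this basis the expected step of a 1.4-fold lower number from compound 1 to compound 4 (0.15 log units; within the scatter) is a modest one, slightly toward a lower number but likely within the scatter. Compound 4 is therefore estimated at 30000 nM in this assay, within a range from 10000 nM to 90000 nM.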

Compound 4, half-maximal cytotoxic concentration: 71300 nM
The estimate for compound 4 lay 2.4-fold (0.38 log units) below the measured number; low and high end bracket the measured number.
By their numbers in this assay, from the lowest: compounds 1, 4 and 2 (each within the scatter of the next, the first and the last beyond it).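

In this assay, the position next to the ring nitrogen now has its first measured step, a 1.7-fold higher number from compound 1 to compound 4 (0.22 log units; within the scatter), for naphthalen-1-yl in place of 4-methoxyphenyl. This change adds a second six-membered aromatic ring of carbon only and removes the hydrogen-bond acceptor of the leaving group, yet the difference stays within the usual scatter, so this test does not separate compound 1 from compound 4. No measurement is at hand that bears on a cause for this result.

What the compounds shown leave open is how this position would respond to a group of another kind, such as a morpholine or a carboxylic acid in place of the aromatic ring. Also open, going by these compounds, is whether a naphthalen-2-yl group at the same place would read like naphthalen-1-yl.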